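Working notes: from phenyl to 4-methoxyphenyl

The source may hold more compounds than are shown below. What is called first, only, known or untested is meant among the compounds shown, and "the series" means these compounds.

Values in a functional assay (thoracic aorta) for inhibition, with Rattus norvegicus as the target; a higher number here means a weaker inhibitor, a lower number a stronger inhibitor:
- compound 1 `O=C(O)c1cc(CCCCNS(=O)(=O)c2ccccc2)c2cccccc1-2`: 570 nM
- compound 2 `CC(C)c1ccc2c(CCCCNS(=O)(=O)c3ccccc3)cc(C(=O)O)c-2cc1`: 70 nM
- compound 3 `CC(C)c1ccc2c(CCCCCCCNS(=O)(=O)c3ccccc3)cc(C(=O)O)c-2cc1`: 120 nM
- compound 4 `COc1ccc(S(=O)(=O)NCCCCc2cc(C(=O)O)c3ccc(C(C)C)ccc2-3)cc1`: not yet measured

Compound 2 at 70 nM and compound 3 at 120 nM lie within the scatter of each other, and both numbers are lower than that of compound 1 at 570 nM. The change to compound 4 is methoxy in place of hydrogen on an aromatic carbon. For the measured compounds named here, the only measured step, an 8.1-fold lower number from compound 1 to compound 2 (0.91 log units; beyond the scatter), is isopropyl in place of hydrogen on an aromatic carbon, a different change, so it gives no size for methoxy. No step beyond the scatter is therefore expected in this assay, and the expected step is a 1.2-fold lower number from compound 2 to compound 4 (0.07 log units; within the scatter). Compound 4 is estimated at 60 nM, with an expected range of 20 nM to 180 nM.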

Compound 4, half-maximal inhibitory concentration: 160 nM
For compound 4 the middle estimate is 2.7-fold (0.43 log units) below the measured one; low and high end bracket the measured number.
By their numbers in this assay, from the lowest: compounds 2, 3 and 4 (each within the scatter of the next, the first and the last beyond it); then compound 1.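

In this assay the position para to a large group on the six-membered aromatic ring of carbon only proves sensitive to substitution: methoxy in place of hydrogen gives a 2.3-fold higher number from compound 2 to compound 4 (0.36 log units; beyond the scatter), beyond the scatter. For the compounds shown here, the only earlier step, an 8.1-fold lower number from compound 1 to compound 2 (0.91 log units; beyond the scatter), came from isopropyl at a different place and ran the opposite way. No measurement here accounts for the rise.

Going by these compounds, whether fluoro or hydroxyl at this place would give a step in the same direction stays open. So does whether methoxy would give a step of similar size on the longer chain of compound 3.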